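From compound 2 to compound 4: a dichlorophenyl addition

The source may report more compounds than this note shows. Statements on the series, on what has been measured and on what is new or still open speak of the compounds shown alone.

Compound 1, `Cc1ccc(S(=O)(=O)Nc2ccc3c(c2)C(=O)N(CCOc2ccc(O)cc2)C3=O)cc1`, gives 100000 nM in an assay on isolated protein for inhibition of lactase/phlorizin hydrolase (Rattus norvegicus), read by colorimetric assay; on this read-out higher numbers stand for weaker inhibition and lower numbers for stronger inhibition.
Compound 2, `Cc1ccc(S(=O)(=O)Nc2ccc3c(c2)C(=O)N(C)C3=O)cc1`, reaches only the limit of > 200000 nM in this assay.
Compound 3, `O=C1c2ccccc2C(=O)N1CCNc1ccccc1`, likewise reaches only the limit of > 200000 nM in this assay.

Compound 2 therefore sits at the limit of > 200000 nM in this assay, at which 2 of the 3 values shown sit, so no number, only a limit, is known for it. Within the data shown here, the single step measured so far, an at least 2.0-fold higher number from compound 1 to compound 2 (0.30 log units; that floor lies within the scatter), removed the (4-hydroxyphenoxy)methyl group from the saturated chain carbon bound to the amide-type nitrogen in the ring and carried the value from a number up to that limit, a floor that lies within the scatter.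

Compound 4, `Cc1ccc(S(=O)(=O)Nc2ccc3c(c2)C(=O)N(Cc2ccc(Cl)c(Cl)c2)C3=O)cc1`, carries the change (3,4-dichlorophenyl in place of hydrogen on a saturated chain carbon bound to an amide-type nitrogen in a ring). Among the measured compounds shown here, this runs the other way round from the one measured step: a group is added rather than taken away at the same place. The measured step gives no sign that a substituent there moves the number beyond the scatter, so only a small shift toward a lower number, if any, is expected for compound 4, with a real chance that only a limit is again reported.

Compound 4 is expected at 150000 nM, within 40000 nM to 300000 nM. The expected step of an at least 1.3-fold lower number from compound 2 to compound 4 (0.12 log units; that floor lies within the scatter) is thus modest and toward stronger inhibition.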

Compound 4, half-maximal inhibitory concentration: 101000 nM
Compound 4: middle estimate off by 1.5-fold (0.17 log units), on the high side; low and high end bracket the measured number.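

The change of hydrogen to 3,4-dichlorophenyl on this saturated chain carbon gives an at least 1.9-fold lower number from compound 2 to compound 4 (0.29 log units; that floor lies within the scatter) in this assay and so replaces a limit with a number at this place. On these data alone, compound 2 has only a limit, so the true size of this step is unknown and its floor cannot be told from scatter: the limit of > 200000 nM in this assay, at which 2 of the 4 values shown sit. Two substituents with different names and atoms also read alike at this place, since exchanging (4-hydroxyphenoxy)methyl for 3,4-dichlorophenyl gives a 1.0-fold higher number from compound 1 to compound 4 (0.00 log units; within the scatter) and therefore does not separate them in this assay.

The compounds shown leave open whether the chlorine atoms matter at all, which a plain benzyl group on the same nitrogen would address, and whether a short alkyl chain such as ethyl would also give a number rather than a limit. Among these compounds, they also leave open whether a carboxylic acid or an amine at the end of a longer chain here would bring the number clearly below the values of compound 1 and compound 4, which so far form the only measured pair with a number at this place.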